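Bromine for chlorine on two ester cores

The source may hold more compounds than are shown below. What is called first, only, known or untested is meant among the compounds shown, and "the series" means these compounds.

The four compounds share a saturated ring ester of a halogen-substituted benzene; they differ only in the halogen and where it sits. Compound 1 `CC(C)[C@@H]1CC[C@@H](C)C[C@H]1OC(=O)c1ccc(Cl)cc1` carries a chloro group, and in a physicochemical assay for lipophilicity, measured as octanol-water partition (a higher number here means a more lipophilic compound, a lower number a more polar compound), compound 1 gives 5.34. Compound 2 `CC(C)[C@@H]1CC[C@@H](C)C[C@H]1OC(=O)c1ccc(Br)cc1` differs from compound 1 by bromo in place of chloro on an aromatic carbon, and in this assay compound 2 gives 5.61. The exchange gave a number 0.27 log units higher from compound 1 to compound 2 (within the scatter).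

Compound 3 `CC(C)[C@@H]1CC[C@@H](C)C[C@H]1OC(=O)c1ccccc1Cl` has the same atoms as compound 1, joined differently; the difference between the two cores is not broken down here. In this assay compound 3 gives 5.34, level with compound 1 at the digits shown, and its value and that of compound 2 lie within the scatter of each other.

Compound 4 `CC(C)[C@@H]1CC[C@@H](C)C[C@H]1OC(=O)c1ccccc1Br` has not yet been measured. It differs from compound 3 by bromo in place of chloro on an aromatic carbon. This is the same kind of change as that between compound 1 and compound 2, but not the same: there the group sits para to a large group, here ortho to a large group. Within the data shown here, the only exchange of this kind already measured gave a number 0.27 log units higher from compound 1 to compound 2 (within the scatter), and that single step is the whole ground for the expectation. Compound 4 is therefore expected to move by a number 0.26 log units higher from compound 3 to compound 4 (within the scatter). The estimate for compound 4 in this assay is 5.6.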

Compound 4, partition coefficient: 5.61
The estimate for compound 4 lay 0.01 log units below the measured number; measured number inside the range.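

In this assay, bromo in place of chloro gave a number 0.27 log units higher from compound 3 to compound 4 (within the scatter), and on the other core the same exchange gave a number 0.27 log units higher from compound 1 to compound 2 (within the scatter), so the step reads alike on both cores at the digits printed, including where the group sits ortho to a large group. This shows that, across these two pairs, the step measured on one core served as a fair guide to the step on the other; but each step lies within the scatter, so the pairs do not establish that the exchange moves the number at all on either core, and two pairs set no rule for any further core. No measurement at hand bears on why the two steps agree.

The compounds shown leave open whether the same agreement would appear with fluoro or iodo as the entering group, since chloro and bromo are the only halogens among them. They also leave open whether it would survive on a core that carries an amine or a carboxylic acid, or one with an amide in place of the ester.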